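Series notes: aryl change on the carbonyl carbon

The source may report more compounds than this note shows. Statements on the series, on what has been measured and on what is new or still open speak of the compounds shown alone.

Measured so far:
- compound 1 `COc1ccc(-c2cc3ccccc3nc2/C=C/C(=O)c2ccc(OC)cc2OC)cc1`, in a functional assay on A549 cells (Homo sapiens) for antiproliferative activity, read by XTT assay, with a stated time of 72 h (on this read-out lower numbers stand for stronger inhibition and higher numbers for weaker inhibition), compound 1 gives 7990 nM
- compound 2 `COc1ccc(-c2cc3ccccc3nc2/C=C/C(=O)c2ccc(OC)c(OC)c2)cc1`, in this assay compound 2 gives 8860 nM

Among the measured compounds shown here, compound 2 holds the highest of the two numbers in this assay, its only neighbour being compound 1 at a 1.1-fold higher number from compound 1 to compound 2 (0.04 log units; within the scatter), so the two sit within the scatter and no order between them is claimed.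

Compound 3 `COc1ccc(-c2cc3ccccc3nc2/C=C/C(=O)c2ccc([N+](=O)[O-])cc2)cc1` has not been measured. It differs from compound 2 by 4-nitrophenyl in place of 3,4-dimethoxyphenyl on a carbonyl carbon. For the measured compounds named here, the one measured step, a 1.1-fold higher number from compound 1 to compound 2 (0.04 log units; within the scatter), also changes the aryl group on the carbonyl carbon, but it moves a methoxy around a ring and does not trade methoxy for nitro, so it bears only loosely on the new change; it shows that such aryl changes left the number within the scatter. Nothing measured speaks to a nitro group here. The expected step in this assay is therefore a 1.0-fold higher number from compound 2 to compound 3 (0.01 log units; within the scatter), a change not clearly beyond the scatter, with a wide range to cover the untested group. Compound 3 is estimated at 9000 nM, between 3000 nM and 30000 nM.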

Compound 3, half-maximal inhibitory concentration: 6310 nM
For compound 3 the middle estimate is 1.4-fold (0.15 log units) above the measured one; measured number inside the range.
By their numbers in this assay, from the lowest: compounds 3, 1 and 2 (each within the scatter of the next).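

In this assay, 4-nitrophenyl on the carbonyl carbon gives a 1.4-fold lower number from compound 2 to compound 3 (0.15 log units; within the scatter) and a 1.3-fold lower number from compound 1 to compound 3 (0.10 log units; within the scatter), so both steps stay within the scatter. The earlier pair showed only a methoxy moved around the ring, whereas these steps show that, among the three compounds, exchanging either dimethoxyphenyl group for a nitro-bearing phenyl also leaves the read-out within the scatter, with no order among the three compounds. No supporting measurement is available to explain this result.

As far as these compounds go, it remains open whether an amine or a carboxylic acid on this phenyl ring, or a saturated ring in its place, would move the number beyond the scatter. From the compounds shown here alone, the shared core is unchanged across all three compounds, so the effect of changes elsewhere on it also remains open.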